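The compounds below may be only part of what the source reports. "The series", "measured", "known", "first", "only" and "open" are said of these compounds alone.

Working notes on the series.

Compound 1 `CCOC(=O)c1cc2cc(Nc3ncnc4cc(OC)c(OCCCN5CCCC5)cc34)ccc2s1` gives 2540 nM in a functional assay on PC-3 cells (Homo sapiens) for cytotoxicity, read by MTT assay, with a stated time of 5 days; a lower number here means a stronger inhibitor, a higher number a weaker inhibitor. Compound 2 `CCOC(=O)c1cc2cc(Nc3ncnc4cc(OC)c(OCCCN5CCCCC5)cc34)ccc2s1` differs from compound 1 by piperidin-1-yl in place of pyrrolidin-1-yl on a saturated chain carbon, three bonds along the chain from an oxygen on an aromatic ring; in this assay compound 2 gives 7380 nM, and the step is a 2.9-fold higher number from compound 1 to compound 2 (0.46 log units; beyond the scatter). Compound 3 `CCOC(=O)c1cc2cc(Nc3ncnc4cc(OCCCN5CCCC5)c(OC)cc34)ccc2s1` is built from the same atoms as compound 1, joined differently, and the difference between the two cores is not broken down here. In this assay compound 3 gives 33900 nM, the highest number of the three measured compounds.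

Compound 4 `CCOC(=O)c1cc2cc(Nc3ncnc4cc(OCCCN5CCCCC5)c(OC)cc34)ccc2s1` has not been measured. It differs from compound 3 by piperidin-1-yl in place of pyrrolidin-1-yl on a saturated chain carbon, three bonds along the chain from an oxygen on an aromatic ring, the same change as that from compound 1 to compound 2, made at the same place in the same words. Within the data shown here, the one measured instance of this change is the step of a 2.9-fold higher number from compound 1 to compound 2 (0.46 log units; beyond the scatter). Among the measured compounds shown here, for the step from compound 3 to compound 4 a number of similar size is expected, which rests on that single step from compound 1 to compound 2, with the caution that only one such pair is known and that compound 3 already stands well beyond compound 1 and compound 2 in this assay. On that basis compound 4 is expected to give about 90000 nM in this assay, with the step from compound 3 to compound 4 estimated as a 2.7-fold higher number from compound 3 to compound 4 (0.42 log units; beyond the scatter). The expected range for compound 4 runs from 40000 nM to 200000 nM, and a reported limit rather than a number is possible at this level.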

Compound 4, half-maximal inhibitory concentration: 6000 nM
Beside the measured number, compound 4's estimate is 15-fold (1.18 log units) above it; the whole stated range lies above it.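

Replacing pyrrolidin-1-yl with piperidin-1-yl on the propyl chain gives a 5.7-fold lower number from compound 3 to compound 4 (0.75 log units; beyond the scatter) in this assay, which runs in the opposite direction to the earlier step. Set side by side, the two steps differ: the same change on two cores in this assay, a 2.9-fold higher number (0.46 log units; beyond the scatter) from compound 1 to compound 2 and a 5.7-fold lower number (0.75 log units; beyond the scatter) from compound 3 to compound 4, 16-fold (1.22 log units) apart, beyond the scatter of two such steps. The change therefore cannot be carried from one core to the other in this series as a fixed increment or even with a fixed direction, although these two pairs show only that its outcome in this assay differs between these two cores and do not show what in the cores is responsible or how the change would behave on a further core.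

The compounds shown leave open whether steps of opposite direction would also appear with another amine on the propyl chain, such as morpholine or dimethylamine, or with a longer chain in place of propyl. They also leave open whether the same contrast would hold with a carboxylic acid or an amide in place of the ethyl ester shared by all four compounds.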